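Trimming the piperidine substituent: from carbamate to carbamoyl

This account rests on a few compounds, and the source may have more. Where it says the series, first, only, none or still open, it means among the compounds named here.

Compound 1 `CC(C)(C)OC(=O)NCC1CCCN(C(=O)CN2CN(c3ccccc3)C3(CCN(C(=O)c4ccc(C5CCCCC5)cc4)CC3)C2=O)C1` gives 3800 nM in an assay on HEK293 cells for displacement of a labelled ligand from NPC1-like intracellular cholesterol transporter 1 (Homo sapiens); on this read-out higher numbers stand for weaker inhibition and lower numbers for stronger inhibition.
For compound 2 `CC(C)(C)OC(=O)NCCCCNC(=O)CN1CN(c2ccccc2)C2(CCN(C(=O)c3ccc(C(C)(C)C)cc3)CC2)C1=O` this assay shows "not determined" (no result reported), with no result reported.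
Compound 3 `CC(C)(C)c1ccc(C(=O)N2CCC3(CC2)C(=O)N(CC(=O)N2CCN(S(C)(=O)=O)CC2)CN3c2ccccc2)cc1` gives 19000 nM in this assay.

Among the numbers shown, compound 1 stands lowest; compound 3 sits far from it, and their gap lies beyond the scatter. Compound 4 `NC(=O)C1CCCN(C(=O)CN2CN(c3ccccc3)C3(CCN(C(=O)c4ccc(C5CCCCC5)cc4)CC3)C2=O)C1` is not yet measured. It differs from compound 1 in one place: carbamoyl in place of ((tert-butoxycarbonyl)amino)methyl on a saturated ring carbon. Among the measured compounds shown here, no step between two measured compounds matches this change, so the expectation rests on compound 1 alone. The estimated step from compound 1 to compound 4 in this assay is a 2.1-fold higher number from compound 1 to compound 4 (0.32 log units; beyond the scatter), expected toward weaker inhibition and beyond the scatter. Compound 4 is therefore expected to give 8000 nM, with a range from 2500 nM to 25000 nM.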

Compound 4, half-maximal inhibitory concentration: 3100 nM
The estimate for compound 4 lay 2.6-fold (0.41 log units) above the measured number; the range from low to high includes it.
By their numbers in this assay, from the lowest: compounds 4 and 1 (each within the scatter of the next); then compound 3.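

In this assay, this ring carbon, two ring bonds from the ring nitrogen, accepts a far smaller group: carbamoyl in place of ((tert-butoxycarbonyl)amino)methyl is a 1.2-fold lower number from compound 1 to compound 4 (0.09 log units; within the scatter), so the number holds with 3 heavy atoms instead of 9. Nothing available on these compounds bears on the reason for this result. Going by these compounds, it remains open whether an amine, a carboxylic acid or a plain hydrogen on this ring carbon would give a number beyond the scatter from compound 4.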